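The source may report more compounds than this note shows. Statements on the series, on what has been measured and on what is new or still open speak of the compounds shown alone.

Compound 2 `COc1cc(Oc2cccc(Nc3ccccc3)c2)cc(OC)c1CNCc1ccccc1` gives 5020 nM in a functional assay on HCT-15 cells (Homo sapiens) for inhibition, read by MTT assay, with a stated time of 72 h (on this read-out lower numbers stand for stronger inhibition and higher numbers for weaker inhibition), and compound 1 `CCN1CCN(Cc2c(OC)cc(Oc3cccc(Nc4ccccc4)c3)cc2OC)CC1` gives 5090 nM, so the two stand together, the step of a 1.0-fold lower number from compound 1 to compound 2 (0.01 log units; within the scatter) being within the scatter. Compound 3 `COc1cc(Oc2cccc(Nc3ccccc3)c2)cc(OC)c1CNCc1ccc(O)cc1` differs from compound 2 by hydroxy in place of hydrogen on an aromatic carbon. Among the measured compounds shown here, only one measured step exists, and it concerns another part of the molecule, so nothing measured speaks directly to this change; compound 3 is therefore expected to show no step beyond the scatter, a 1.0-fold lower number from compound 2 to compound 3 (0.00 log units; within the scatter). Compound 3 is estimated at 5000 nM, with a range from 2500 nM to 10000 nM.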

Compound 3, half-maximal inhibitory concentration: 3430 nM
The estimate for compound 3 lay 1.5-fold (0.16 log units) above the measured number, within the range that was stated.
By their numbers in this assay, from the lowest: compounds 3, 2 and 1 (each within the scatter of the next).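

In this assay, hydroxy on the aromatic carbon para to a large group gives a 1.5-fold lower number from compound 2 to compound 3 (0.17 log units; within the scatter) and so shows that this position carries the 4-hydroxybenzyl group with no step beyond the scatter. The wider exchange of 4-ethylpiperazin-1-yl for (4-hydroxybenzyl)amino gives a 1.5-fold lower number from compound 1 to compound 3 (0.17 log units; within the scatter) and leaves all three compounds together. No measurement shown here offers an explanation for these numbers.

Going by these compounds, whether methoxy, an amine or a carboxylic acid on this ring carbon would give a step beyond the scatter remains open. So does the outcome of hydroxy on the other carbons of this ring.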